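Swapping a Chlorophenyl for a Furan Ring

The compounds below may be only part of what the source reports. "The series", "measured", "known", "first", "only" and "open" are said of these compounds alone.

Measured compounds:
Compound 1 `Nc1nc(-c2ccccc2)cn2cc(-c3ccccc3)nc12` gives 23% in an assay on cells for displacement of a labelled ligand from transmembrane domain-containing protein TMIGD3 (Homo sapiens), read by scintillation counting, with a stated time of 120 min, tested at 1 uM; on this read-out lower numbers stand for less inhibition and higher numbers for more inhibition at the one concentration tested (going by the name of the read-out).
Compound 2 `Nc1nc(-c2ccc(Cl)cc2)cn2cc(-c3ccccc3)nc12` gives 1% in this assay.

Among the compounds with values here, on these two numbers, compound 2 stands lowest: the one step recorded, a number 22 percentage points lower from compound 1 to compound 2 (beyond the scatter), was a modest fall brought about by chloro in place of hydrogen on an aromatic carbon. Compound 3 `Nc1nc(-c2ccco2)cn2cc(-c3ccccc3)nc12` has not yet been measured in this assay. It differs from compound 2 by furan-2-yl in place of 4-chlorophenyl on an aromatic carbon. Within the data shown here, no measured step covers an exchange of one ring for another, so the only guidance is the step from compound 1 to compound 2, which shows that adding a chlorine atom to the phenyl ring lowered the read-out. Taking that chlorophenyl away and entering furan-2-yl is expected to move the number back upward, by about a number 14 percentage points higher from compound 2 to compound 3 (beyond the scatter). Compound 3 is therefore estimated at 15%, with a range from 0% to 35%.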

Compound 3, a percentage reported as inhibition, at one concentration (the size of the read-out at that concentration, not a potency): 20%
Compound 3: middle estimate off by 5 percentage points, on the low side, and the stated range covers the measured number.
By their numbers in this assay, from the lowest: compound 2; then compounds 3 and 1 (each within the scatter of the next).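

In this assay the change to furan-2-yl gives a number 19 percentage points higher from compound 2 to compound 3 (beyond the scatter) in this comparison, so the low number of compound 2 does not carry over to every ring at this position. Against plain phenyl, furan-2-yl gives a number 3 percentage points lower from compound 1 to compound 3 (within the scatter) in this comparison, so a five-membered aromatic ring with one oxygen and a six-membered ring of carbon only cannot be told apart here, and among these three groups only 4-chlorophenyl stands apart. Nothing on hand explains this difference between the rings.

As far as these compounds go, it remains open whether the chlorine itself matters or whether another group at the end of the phenyl ring, such as methoxy or fluoro, would lower the number too. Also open, from the compounds shown here alone, is how thiophene, pyridine or a simple amine would read at this position.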